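One swap, two cores: imidazolyl to dimethylamino

The source may report more compounds than this note shows. Statements on the series, on what has been measured and on what is new or still open speak of the compounds shown alone.

Compound 1 `CC(C#CCn1ccnc1)N1CCCC1=O` carries a 1H-imidazol-1-yl group. In a functional assay on the whole organism for agonist activity, with Mus musculus as the target (a higher number here means that more compound is needed for the effect, a lower number that less compound is needed), compound 1 gives only a limit, > 100 mg/kg. Compound 2 `CC(C#CCN(C)C)N1CCCC1=O` differs from it in one place: dimethylamino in place of 1H-imidazol-1-yl on a saturated chain carbon bound to a triple-bonded carbon. In this assay compound 2 gives 6.6 mg/kg, and the step is an at least 15-fold lower number from compound 1 to compound 2 (1.18 log units; beyond the scatter); the starting value sits at the limit of > 100 mg/kg in this assay, at which 2 of the 3 values shown sit. Compound 3 `CC1CCC(=O)N1CC#CCn1ccnc1` has the same atoms as compound 1 joined differently; the difference between the two cores is not broken down here. In this assay compound 3 gives only a limit, > 100 mg/kg. Compound 4 `CC1CCC(=O)N1CC#CCN(C)C` is not yet measured and stands to compound 3 as compound 2 stands to compound 1, the same change: dimethylamino in place of 1H-imidazol-1-yl on a saturated chain carbon bound to a triple-bonded carbon. Because an at least 15-fold lower number from compound 1 to compound 2 (1.18 log units; beyond the scatter) was large, the step of an at least 6.6-fold lower number from compound 3 to compound 4 (0.82 log units; beyond the scatter) is expected to be of comparable size, resting on that single earlier swap alone. Compound 4 is therefore estimated at 15 mg/kg in this assay, between 4 mg/kg and 100 mg/kg.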

Compound 4, dose for half-maximal effect: 3.7 mg/kg
The estimate for compound 4 lay 4.1-fold (0.61 log units) above the measured number; the whole stated range lies above it.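

In this assay the swap to dimethylamino gives an at least 27-fold lower number from compound 3 to compound 4 (1.43 log units; beyond the scatter), so the large drop seen on the core of compound 1 also appears on the core of compound 3. Going by these compounds, the two steps can be compared only loosely, since compound 1 and compound 3 both start from a limit and the true size of each step stays unknown: the same change on two cores in this assay, an at least 15-fold lower number (1.18 log units; beyond the scatter) from compound 1 to compound 2 and an at least 27-fold lower number (1.43 log units; beyond the scatter) from compound 3 to compound 4; the limit leaves it open whether they differ. Two cores show that the change carried over once, not that it will carry over to every other core.

The compounds shown leave open whether another amine, such as diethylamino, would do the same on either core. Also open, on these data alone, is how a longer chain carrying the dimethylamino group would fare in this assay.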